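Estimating a Keto Amide Chain End Against a Limit

This account rests on a few compounds, and the source may have more. Where it says the series, first, only, none or still open, it means among the compounds named here.

- Compound 1 `CC(C)(C)C(O)(O)C(=O)NCCCCCC(=O)Nc1ccccc1`: 54400 nM
- Compound 2 `O=C(CCCCCCC(O)C(F)(F)F)Nc1ccccc1`: > 40000 nM (a limit)

In a functional assay on HCT-116 cells (Homo sapiens) for inhibition, read by colorimetric assay, with a stated time of 3 days (on this read-out higher numbers stand for weaker inhibition and lower numbers for stronger inhibition), compound 2 stands at > 40000 nM, which is a limit and not a number. Compound 3 `CC(=O)C(=O)NCCCCCC(=O)Nc1ccccc1` differs from it as follows: (acetylcarbonyl)amino in place of 3,3,3-trifluoro-2-hydroxypropyl on a saturated chain carbon, five bonds along the chain from a carbonyl carbon. Here (acetylcarbonyl)amino comes in place of 3,3,3-trifluoro-2-hydroxypropyl on a saturated chain carbon, five bonds along the chain from a carbonyl carbon. Among the measured compounds shown here, no measured pair shows this change, so only a small expected step toward stronger inhibition is proposed: an at least 1.1-fold lower number from compound 2 to compound 3 (0.05 log units; that floor lies within the scatter). For the measured compounds named here, the only full number available as a guide is that of compound 1, at 54400 nM. For compound 3 the estimate is 35000 nM, with an expected range from 10000 nM to 100000 nM.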

Compound 3, half-maximal inhibitory concentration: > 100000 nM
Compound 3 ended at the assay's limit (the forecaster's own chance of this, stated with the estimate: 35%); middle value at least 2.8-fold (0.45 log units) away from the limit.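

In this assay, compound 3 gives > 100000 nM, which is a limit of the assay and not a number. On the carbonyl carbon, acetyl in place of 1,1-dihydroxy-2,2-dimethylpropyl gives an at least 1.8-fold higher number from compound 1 to compound 3 (0.26 log units; that floor lies within the scatter), so the acetyl chain end shows no sign of stronger inhibition, although the smallest step the data allow is not beyond the usual scatter. The step from compound 2 cannot be read, because compound 3 sits at a limit and compound 2 has one too: the limit of > 100000 nM in this assay, at which 1 of the 3 values shown sits.

From the compounds shown here alone, it remains open whether an amine or a carboxylic acid at this chain end, or a longer chain, would give a full number in this assay.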